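The source may hold more compounds than are shown below. What is called first, only, known or untested is meant among the compounds shown, and "the series" means these compounds.

Compound 1 `COc1ccc(C2=C(c3cc(OC)c(OC)c(OC)c3)C(=O)C(OC(C)=O)C2)cc1Cl` gives < 1 ug/mL in an ADME assay on HEp-2 cells (Homo sapiens) for cytotoxicity, read by MTT assay, with a stated time of 72 h (a lower number here means a stronger inhibitor, a higher number a weaker inhibitor), which is a limit of the test rather than a number.
Compound 2 `COC(=O)c1cc(C2=C(c3cc(OC)c(OC)c(OC)c3)C(=O)CC2O[SiH2]C(C)(C)C)ccc1OC` gives > 100 ug/mL in this assay, again only a limit.

Compound 2 therefore stands at the weak end of the two values shown, sitting at the limit of > 100 ug/mL in this assay, at which 1 of the 2 values shown sits. Compound 3 `COc1cc(C2=C(c3ccccc3)C(O[SiH2]C(C)(C)C)CC2=O)cc(OC)c1OC` differs from compound 2 by phenyl in place of 4-methoxy-3-(methoxycarbonyl)phenyl on a double-bonded ring carbon. For the measured compounds named here, no measured pair of compounds shares a single change, so the size of this step has no direct precedent. Inhibition is expected to grow by an at least 5.0-fold lower number from compound 2 to compound 3 (0.69 log units; beyond the scatter). Compound 3 is estimated at 20 ug/mL, likely between 3 ug/mL and 100 ug/mL.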

Compound 3, half-maximal inhibitory concentration: > 100 ug/mL
Compound 3 was reported as a limit; the forecaster's own chance of this, stated with the estimate: 35%; middle value at least 5.0-fold (0.69 log units) from the limit.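

Compound 2 and compound 3 both give only limits in this assay, not numbers, so no step can be read between them. As far as these compounds go, whether replacing 4-methoxy-3-(methoxycarbonyl)phenyl with phenyl changes inhibition at all remains open.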